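Clearance in Mice: Swapping Bromo for Cyano on Two Cores

This account rests on a few compounds, and the source may have more. Where it says the series, first, only, none or still open, it means among the compounds named here.

Measured compounds:
- compound 1, `COc1cccc([C@H](c2cc3cc(Br)ccc3nc2OC)[C@@](O)(CCN(C)C)c2cc(SC)nc(SC)c2)c1F`, 13 mL/min/kg
- compound 2, `COc1cccc([C@H](c2cc3cc(C#N)ccc3nc2OC)[C@@](O)(CCN(C)C)c2cc(SC)nc(SC)c2)c1F`, 44 mL/min/kg
- compound 3, `CCSc1cc([C@](O)(CCN(C)C)[C@@H](c2cc3cc(Br)ccc3nc2OC)c2cccc(OC)c2F)cc(SCC)n1`, 3.6 mL/min/kg

These values come from an ADME assay on the whole organism (Mus musculus, strain CD-1) for pharmacokinetics; a higher number here means faster removal of the compound, a lower number slower removal. Compound 3 has the lowest number of the three; its nearest neighbour is compound 1, and compound 2 is furthest away.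

The change from compound 1 to compound 2 is cyano in place of bromo on an aromatic carbon. That step was a 3.4-fold higher number from compound 1 to compound 2 (0.53 log units; beyond the scatter). The two cores differ as shown by a group of 12 heavy atoms (9 carbon, 1 nitrogen, 2 sulfur; one six-membered aromatic ring with 1 hetero atom) in place of a group of 10 heavy atoms (7 carbon, 1 nitrogen, 2 sulfur; one six-membered aromatic ring with 1 hetero atom), on a saturated chain carbon bound to an oxygen on a saturated carbon and two saturated chain carbons, and that step was a 3.6-fold lower number from compound 1 to compound 3 (0.56 log units; beyond the scatter).

Compound 4, `CCSc1cc([C@](O)(CCN(C)C)[C@@H](c2cc3cc(C#N)ccc3nc2OC)c2cccc(OC)c2F)cc(SCC)n1`, has not yet been measured in this assay. It differs from compound 3 by cyano in place of bromo on an aromatic carbon, which sits at the same place as in the earlier pair, so this is the same change made on the other core.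

For compound 4 the step from compound 3 is expected to be a 3.3-fold higher number from compound 3 to compound 4 (0.52 log units; beyond the scatter), resting on the one earlier case of this change, where the step was a 3.4-fold higher number from compound 1 to compound 2 (0.53 log units; beyond the scatter). Compound 4 is therefore estimated to give 12 mL/min/kg in this assay, with a likely range from 5 mL/min/kg to 28 mL/min/kg.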

Compound 4, clearance: 29 mL/min/kg
Compound 4: middle estimate off by 2.4-fold (0.38 log units), on the low side; measured number outside the range, above it.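

Cyano in place of bromo gave a higher number on the second core as well, an 8.1-fold higher number from compound 3 to compound 4 (0.91 log units; beyond the scatter), so in this assay the direction of the change carried over, and the sizes of the two steps cannot be told apart: the same change on two cores in this assay, a 3.4-fold higher number (0.53 log units; beyond the scatter) from compound 1 to compound 2 and an 8.1-fold higher number (0.91 log units; beyond the scatter) from compound 3 to compound 4, 2.4-fold (0.38 log units) apart, within the scatter of two such steps. Seen from the other side, the change of core with cyano in place is a 1.5-fold lower number from compound 2 to compound 4 (0.18 log units; within the scatter), and although that step lies within the scatter, it cannot be called different from the same core change with bromo in place: the same change on two cores in this assay, a 3.6-fold lower number (0.56 log units; beyond the scatter) from compound 1 to compound 3 and a 1.5-fold lower number (0.18 log units; within the scatter) from compound 2 to compound 4, 2.4-fold (0.38 log units) apart, within the scatter of two such steps. This supports carrying the bromo-to-cyano step between these two cores as a rough guide, but two pairs cannot show that it holds on other cores, and they do not explain why clearance changes.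

From the compounds shown here alone, it remains open how a chloro group or a primary amide at the same aromatic carbon would compare with bromo and cyano. Going by these compounds, it is also open whether the step would keep its direction on a core with a longer chain on each sulfur atom.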